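This account rests on a few compounds, and the source may have more. Where it says the series, first, only, none or still open, it means among the compounds named here.

Measured compounds:
compound 1, `O=C(NO)c1ccc(CNC(=O)c2n[nH]cc2NC(=O)c2ccccc2Cl)cc1`, 6420 nM in a functional assay on A-375 cells (Homo sapiens) for inhibition, read by CCK-8 assay, with a stated time of 72 h; a higher number here means a weaker inhibitor, a lower number a stronger inhibitor
compound 2, `Nc1ccccc1NC(=O)c1ccc(CNC(=O)c2n[nH]cc2NC(=O)c2ccccc2F)cc1`, 2270 nM
compound 3, `Nc1ccccc1NC(=O)c1ccc(CNC(=O)c2n[nH]cc2NC(=O)c2ccccc2)cc1`, 1590 nM

Compound 3 stands at the low end of these three numbers. Compound 2 sits within the scatter of compound 3, so the two cannot be told apart; compound 1, whose number is higher by a margin beyond the scatter, is the only one that stands clearly away from compound 3.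

Compound 4, `Nc1ccccc1NC(=O)c1ccc(CNC(=O)c2n[nH]cc2NC(=O)c2ccccc2Cl)cc1`, is not yet measured. It differs from compound 3 by chloro in place of hydrogen on an aromatic carbon.

For the measured compounds named here, the one measured step that bears on the same position is a 1.4-fold lower number from compound 2 to compound 3 (0.15 log units; within the scatter), which shows that exchanging fluoro for hydrogen there leaves the number essentially unchanged. Going by the values given here, compound 1 carries the chloro group of compound 4 but a different group on the other end of the molecule, so its value shows only that a chloro-bearing compound of this series can reach a higher number; no single step separates it from compound 4. On this basis compound 4 is expected to fall close to compound 3, with a step of a 1.3-fold higher number from compound 3 to compound 4 (0.12 log units; within the scatter) that is not expected to exceed the scatter. Compound 4 is therefore estimated at 2100 nM in this assay, within a range from 900 nM to 5000 nM.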

Compound 4, half-maximal inhibitory concentration: 2110 nM
Beside the measured number, compound 4's estimate is 1.0-fold (0.00 log units) below it; the measured number falls inside the stated range.
By their numbers in this assay, from the lowest: compounds 3, 4 and 2 (each within the scatter of the next); then compound 1.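

In this assay, the step with chloro in place of hydrogen on this aromatic carbon reads a 1.3-fold higher number from compound 3 to compound 4 (0.12 log units; within the scatter), and the step with chloro in place of fluoro reads a 1.1-fold lower number from compound 2 to compound 4 (0.03 log units; within the scatter), so hydrogen, fluoro and chloro at this place cannot be told apart among compounds that share the 2-aminophenyl amide. Until now only fluoro had been compared with hydrogen here, and the result extends that finding to a second halogen, so the phenyl to 2-chlorophenyl change leaves the number within the scatter. Compound 4 also gives compound 1 a partner that differs in one place, and the step of a 3.0-fold lower number from compound 1 to compound 4 (0.48 log units; beyond the scatter), with 2-aminophenyl in place of hydroxy on an amide-type nitrogen, lies beyond the scatter, which places the clear difference at that end of the molecule and not at the chloro group.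

As far as these compounds go, whether a methoxy group, an amine, a carboxylic acid or a bromo group on the same aromatic carbon would also stay within the scatter remains open. Nothing shown here accounts for why these numbers fall as they do.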